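The source may report more compounds than this note shows. Statements on the series, on what has been measured and on what is new or still open speak of the compounds shown alone.

In a functional assay on A549 cells (Homo sapiens) for inhibition, read by CCK-8 assay, with a stated time of 72 h, tested at 2 uM (on this read-out higher numbers stand for more inhibition of growth at the one concentration tested and lower numbers for less inhibition of growth), compound 1 (`Nc1ccccc1NC(=O)/C=C/c1ccc(CSc2cccc(F)c2)cc1`) gives 50.7% and compound 2 (`Nc1ccccc1NC(=O)/C=C/c1ccc(CSc2ccc(C(F)(F)F)cn2)cc1`) gives 51.7%, while compound 3 (`Nc1ccccc1NC(=O)/C=C/c1ccc(CSc2cccc3ccccc23)cc1`) gives 59.3% on the same read-out. Compound 3 is not separated from the other two, the steps to it being a number 8.6 percentage points higher from compound 1 to compound 3 (within the scatter) and a number 7.6 percentage points higher from compound 2 to compound 3 (within the scatter) for exchanges on the sulfur. Among the measured compounds shown here, compound 4 (`CC(C)(C)c1ccc(SCc2ccc(/C=C/C(=O)Nc3ccccc3N)cc2)cc1`) differs from compound 3 by 4-(tert-butyl)phenyl in place of naphthalen-1-yl on a sulfur as its one change, that is 4-(tert-butyl)phenyl in place of naphthalen-1-yl on a sulfur. For the measured compounds named here, no measured step covers this exact exchange. The closest guide is the set of other exchanges at that sulfur, which also includes a number 1 percentage points higher from compound 1 to compound 2 (within the scatter) as the third step. None of the three steps leaves the scatter, so no step beyond the scatter is expected in this assay for this exchange. The estimated step is a number 5.3 percentage points lower from compound 3 to compound 4 (within the scatter) and leans only weakly toward the other two values. Compound 4 is estimated at 54% with an expected range from 42% to 66% on this read-out.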

Compound 4, percent growth inhibition at one concentration: 71.5%
Compound 4: middle estimate off by 17.5 percentage points, on the low side; measured number outside the range, above it.
By their numbers in this assay, from the lowest: compounds 1, 2 and 3 (each within the scatter of the next); then compound 4.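

a number 12.2 percentage points higher from compound 3 to compound 4 (beyond the scatter) and a number 19.8 percentage points higher from compound 2 to compound 4 (beyond the scatter) and a number 20.8 percentage points higher from compound 1 to compound 4 (beyond the scatter) are the first steps beyond the scatter at the sulfur in this assay for this series. The position therefore responds to the group on the sulfur, which the earlier exchanges could not show. The 4-(tert-butyl)phenyl group has the same count of heavy atoms as naphthalen-1-yl but one aromatic ring instead of two, so among these compounds a second ring is not required for the highest number. No supporting data bear on the reason for this rise.

From the compounds shown here alone, it remains open whether the gain depends on the tert-butyl group itself, which a 4-methylphenyl or 4-methoxyphenyl group on the sulfur would test. A single concentration also leaves open how the compounds compare across a range of doses.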